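The source may hold more compounds than are shown below. What is called first, only, known or untested is meant among the compounds shown, and "the series" means these compounds.

Working notes on the series. Compound 1 `C=Cc1ccc(S(=O)(=O)Nc2ccc3oc(-c4ccccc4)nc3c2)cc1` is a sulfonamide carrying a 4-vinylphenyl group on the sulfonyl sulfur. In an assay on cells for inhibition of HSP60/HSP10 (Homo sapiens), with a stated time of 60 min (a higher number here means a weaker inhibitor, a lower number a stronger inhibitor), compound 1 gives > 100000 nM, which is a limit of the assay and not a number. Compound 2 `O=S(=O)(Nc1ccc2oc(-c3ccccc3)nc2c1)c1ccc(Cl)c(C(F)(F)F)c1` carries a chlorinated, trifluoromethyl-bearing phenyl ring at the same position. In this assay compound 2 gives > 100000 nM, again a limit rather than a number. Both values therefore sit at the limit of > 100000 nM in this assay, at which 2 of the 2 values shown sit, so compound 1 cannot be placed relative to compound 2 beyond noting that neither reached a measurable inhibition.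

Compound 3 `O=S(=O)(Nc1ccc2oc(-c3ccccc3)nc2c1)c1cccc(Cl)c1` is the next member, still to be measured in this assay. It differs from compound 1 by 3-chlorophenyl in place of 4-vinylphenyl on a sulfonyl sulfur. For the measured compounds named here, no measured step connects these two compounds, so the size of the change is open. Given that compound 1 sits at a limit > 100000 nM, compound 3 is expected to remain there too, with a step that the limit leaves unreadable from compound 1 to compound 3 that is not expected to exceed the usual scatter. Compound 3 is estimated at 150000 nM in this assay. The expected range for compound 3 runs from 40000 nM to 500000 nM, with a limit being the most likely outcome.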

Compound 3, half-maximal inhibitory concentration: > 100000 nM
Compound 3 gave a limit, no number (the forecaster's own chance of this, stated with the estimate: 80%); the middle value lies beyond the limit too.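

In this assay, for the compounds shown here, compound 3 gives > 100000 nM, a limit and not a number, so no step between compound 1 and compound 3 can be read: the limit of > 100000 nM in this assay, at which 3 of the 3 values shown sit. The compounds shown leave open whether any group on the sulfonyl sulfur gives a measurable value in this assay.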